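Lengthening the Amine Chain One Carbon Further

A few compounds are considered here, and "the series" means these few. Any claim that something is new, unique, unknown or untested is made for them only; others in the source may bear on it.

Three compounds share one core and differ only in the length of the chain that links a dimethylamino group to an oxygen on the aromatic ring. Compound 1 `CN(C)CCCCCCCOc1ccc2oc(-c3ccccc3)cc(=O)c2c1` gives 165 nM in an assay on isolated protein (Cavia porcellus) with Sigma non-opioid intracellular receptor 1 (Homo sapiens) as the target, read by radioligand binding; on this read-out lower numbers stand for stronger inhibition and higher numbers for weaker inhibition. Compound 2 `CN(C)CCCCCCCCOc1ccc2oc(-c3ccccc3)cc(=O)c2c1` gives 227 nM in this assay, and compound 3 `CN(C)CCCCCCCCCOc1ccc2oc(-c3ccccc3)cc(=O)c2c1` gives 334 nM in this assay. Compound 3 therefore holds the highest of the three numbers; the two steps that lead to it are a 1.5-fold higher number from compound 2 to compound 3 (0.17 log units; within the scatter) and a 2.0-fold higher number from compound 1 to compound 3 (0.31 log units; beyond the scatter).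

Compound 4 `CN(C)CCCCCCCCCCOc1ccc2oc(-c3ccccc3)cc(=O)c2c1` has not yet been measured. It differs from compound 3 by (dimethylamino)methyl in place of dimethylamino on a saturated chain carbon, nine bonds along the chain from an oxygen on an aromatic ring. The two earlier single-carbon extensions bear on this change: a 1.4-fold higher number from compound 1 to compound 2 (0.14 log units; within the scatter) and a 1.5-fold higher number from compound 2 to compound 3 (0.17 log units; within the scatter). Both point upward and both are small, so a further small rise is expected. The step is estimated at a 1.4-fold higher number from compound 3 to compound 4 (0.16 log units; within the scatter). Compound 4 is expected to give about 480 nM in this assay, within a range from 260 nM to 900 nM.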

Compound 4, half-maximal inhibitory concentration: 297 nM
The estimate for compound 4 lay 1.6-fold (0.21 log units) above the measured number, and the stated range covers the measured number.
By their numbers in this assay, from the lowest: compounds 1, 2, 4 and 3 (each within the scatter of the next, the first and the last beyond it).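

Adding one more carbon gives a 1.1-fold lower number from compound 3 to compound 4 (0.05 log units; within the scatter), so the small rises seen on the shorter chains do not carry on at this position, and the same change reads alike on the shorter and the longer chains: the same change on two cores in this assay, a 1.4-fold higher number (0.14 log units; within the scatter) from compound 1 to compound 2 and a 1.1-fold lower number (0.05 log units; within the scatter) from compound 3 to compound 4, 1.5-fold (0.19 log units) apart, within the scatter of two such steps Over longer spans of the chain, the numbers show a 1.3-fold higher number from compound 2 to compound 4 (0.12 log units; within the scatter) and a 1.8-fold higher number from compound 1 to compound 4 (0.26 log units; within the scatter), and the matching comparison of larger extensions also agrees: the same change on two cores in this assay, a 2.0-fold higher number (0.31 log units; beyond the scatter) from compound 1 to compound 3 and a 1.3-fold higher number (0.12 log units; within the scatter) from compound 2 to compound 4, 1.5-fold (0.19 log units) apart, within the scatter of two such steps The only step beyond the scatter remains a 2.0-fold higher number from compound 1 to compound 3 (0.31 log units; beyond the scatter), so chain length has little measurable effect over this stretch, and compound 4 does not extend that difference.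

Going by these compounds, whether a still longer chain would stay in this same range remains open, as does the effect of a chain shorter than that of compound 1. On these data alone, all four compounds carry dimethylamino, so what another amine, such as piperidine or morpholine, would give at the chain end also remains open.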